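Furan-2-yl in Place of Isopropyl on a Carbonyl Carbon

The source may hold more compounds than are shown below. What is called first, only, known or untested is meant among the compounds shown, and "the series" means these compounds.

In a functional assay on A-375 cells (Homo sapiens) for cytotoxicity, read by MTT assay (on this read-out lower numbers stand for stronger inhibition and higher numbers for weaker inhibition), compound 1 `COc1ccc(/C=C/C(=O)c2ccc(OC)c3c2OC(C)(C)C=C3)cc1O` gives 800 nM. Among the measured compounds shown here, compound 2 `COc1ccc(/C=C/C(=O)c2ccc(OC)c3c2OC(C)(C)C=C3)cc1OC(=O)C(C)C`, with isopropylcarbonyl in place of hydrogen on an oxygen on an aromatic ring, gives 310 nM, the lower of the two numbers so far. Compound 3 `COc1ccc(/C=C/C(=O)c2ccc(OC)c3c2OC(C)(C)C=C3)cc1OC(=O)c1ccco1` keeps the shared core and the carbonyl but changes the group on that carbonyl: furan-2-yl in place of isopropyl on a carbonyl carbon. For the measured compounds named here, only one measured step bears on this change: a 2.6-fold lower number from compound 1 to compound 2 (0.41 log units; beyond the scatter). That modest step shows what adding isopropylcarbonyl did, not what furan-2-yl in place of isopropyl will do. Going by the values given here, no measured compound carries furan-2-yl, so the data point in no direction, and no change beyond the usual scatter is expected. In this assay the expected step is a 1.0-fold lower number from compound 2 to compound 3 (0.01 log units; within the scatter). For compound 3 the estimated value is 300 nM, with an expected range from 110 nM to 800 nM.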

Compound 3, half-maximal inhibitory concentration: 680 nM
Compound 3: middle estimate off by 2.3-fold (0.36 log units), on the low side, within the range that was stated.
By their numbers in this assay, from the lowest: compound 2; then compounds 3 and 1 (each within the scatter of the next).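

In this assay the group on this carbonyl carbon matters: furan-2-yl in place of isopropyl gives a 2.2-fold higher number from compound 2 to compound 3 (0.34 log units; beyond the scatter) and so gives back most of what isopropylcarbonyl had gained. Putting a carbonyl group on the oxygen on the aromatic ring does not by itself lower the number, as (furan-2-yl)carbonyl in place of hydrogen gives only a 1.2-fold lower number from compound 1 to compound 3 (0.07 log units; within the scatter) and leaves compound 3 level with compound 1.

Among the compounds shown here, with only two groups on this carbonyl carbon, no trend across groups can be drawn. Going by these compounds, it remains open whether a longer chain such as n-butyl, a phenyl ring or an amine in that place would match isopropyl or lower the number further. Nothing measured here explains why isopropyl and furan-2-yl differ.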